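Swapping a Substituted Phenyl for Vinylphenyl on the Shared Core

The compounds below may be only part of what the source reports. "The series", "measured", "known", "first", "only" and "open" are said of these compounds alone.

Compound 1 `COc1ccc(-c2cc3nccc(-c4cc(OC)c(OC)c(OC)c4)n3n2)cc1F` gives 3950 nM in a functional assay on B16-F0 cells (Mus musculus) for inhibition, read by CCK-8 assay, with a stated time of 48 h (on this read-out higher numbers stand for weaker inhibition and lower numbers for stronger inhibition), the highest of the three numbers recorded. Compound 2 `COc1cc(-c2ccnc3cc(-c4c[nH]c5ccccc45)nn23)cc(OC)c1OC` gives 40 nM, and compound 3 `COc1cc(-c2ccnc3cc(-c4ccc5cnn(C)c5c4)nn23)cc(OC)c1OC` gives 1000 nM; the shift a 99-fold lower number from compound 1 to compound 2 (1.99 log units; beyond the scatter) is large, while a 4.0-fold lower number from compound 1 to compound 3 (0.60 log units; beyond the scatter) is only modest. Compound 4 `C=Cc1ccc(-c2cc3nccc(-c4cc(OC)c(OC)c(OC)c4)n3n2)cc1` carries the change (4-vinylphenyl in place of 3-fluoro-4-methoxyphenyl on an aromatic carbon). Neither measured step matches it closely: those steps bring in 1H-indol-3-yl or 1-methyl-1H-indazol-6-yl, whereas 4-vinylphenyl is a plainer replacement that drops the methoxy and fluorine. One therefore expects at most a modest step in this assay, more likely downward than upward, since compound 3 already showed a 4.0-fold lower number from compound 1 to compound 3 (0.60 log units; beyond the scatter). The estimated value for compound 4 is 2500 nM, ranging from 600 nM to 10000 nM, an expected 1.6-fold lower number from compound 1 to compound 4 (0.20 log units; within the scatter).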

Compound 4, half-maximal inhibitory concentration: 788 nM
Compound 4: the middle estimate sits 3.2-fold (0.50 log units) above what was measured; measured number inside the range.
By their numbers in this assay, from the lowest: compound 2; then compounds 4 and 3 (each within the scatter of the next); then compound 1.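

In this assay, the methoxy and fluorine prove dispensable at this position: the carbon-only 4-vinylphenyl gives a 5.0-fold lower number from compound 1 to compound 4 (0.70 log units; beyond the scatter). A single six-membered ring also stands level with the fused 1-methyl-1H-indazol-6-yl, at a 1.3-fold lower number from compound 3 to compound 4 (0.10 log units; within the scatter), while the 1H-indol-3-yl remains well apart, with a 20-fold higher number from compound 2 to compound 4 (1.29 log units; beyond the scatter). No measurement is available that explains these differences.

The compounds shown leave open whether the vinyl double bond itself matters. How a 4-ethylphenyl or a 4-aminophenyl would compare at this position cannot be told from them.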